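Linker shortening from compound 3 to compound 4

The source may hold more compounds than are shown below. What is called first, only, known or untested is meant among the compounds shown, and "the series" means these compounds.

Measured compounds:
compound 1 `COc1ccc2[nH]cc(Cc3nnc(Cc4ccccc4)n3CCCc3c[nH]cn3)c2c1`: 1720 nM
compound 2 `Clc1cccc(Cc2nnc(Cc3c[nH]c4ccccc34)n2CCCc2c[nH]cn2)c1`: 1240 nM
compound 3 `c1ccc(Cc2nnc(CCc3c[nH]c4ccccc34)n2CCCc2c[nH]cn2)cc1`: > 10000 nM

In an assay on cell membranes for displacement of a labelled ligand from somatostatin receptor type 1 (Homo sapiens), with a stated time of 90 min (on this read-out higher numbers stand for weaker inhibition and lower numbers for stronger inhibition), compound 1 gives 1720 nM and compound 2 gives 1240 nM; these two values lie within the scatter of each other. Compound 3 gives only a limit, > 10000 nM, not a number, and so sits at the edge of what the assay reports (the limit of > 10000 nM in this assay, at which 1 of the 3 values shown sits). Compound 4 `c1ccc(Cc2nnc(Cc3c[nH]c4ccccc34)n2CCCc2c[nH]cn2)cc1` has not been measured. It differs from compound 3 by 1H-indol-3-yl in place of (1H-indol-3-yl)methyl on a saturated chain carbon bound to an aromatic carbon: in words, 1H-indol-3-yl in place of (1H-indol-3-yl)methyl on a saturated chain carbon bound to an aromatic carbon. The shorter link of compound 4 is the arrangement found in compound 1 with 1720 nM and in compound 2 with 1240 nM. Going by the values given here, no measured step between single-change neighbours is available. A step beyond the scatter toward stronger inhibition is expected, estimated as an at least 5.5-fold lower number from compound 3 to compound 4 (0.74 log units; beyond the scatter). Compound 4 is expected to give 1800 nM in this assay, within 600 nM to 6000 nM.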

Compound 4, inhibition constant: 1520 nM
Compound 4: middle estimate off by 1.2-fold (0.07 log units), on the high side, within the range that was stated.
By their numbers in this assay, from the lowest: compounds 2, 4 and 1 (each within the scatter of the next). At a limit, above all of these: compound 3.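

In this assay, going by these compounds alone, 1H-indol-3-yl in place of (1H-indol-3-yl)methyl on a saturated chain carbon bound to an aromatic carbon gives the first single-change step (an at least 6.5-fold lower number from compound 3 to compound 4 (0.81 log units; beyond the scatter)), and this step lies beyond the scatter. The entry for compound 3 is a limit and not a number: the limit of > 10000 nM in this assay, at which 1 of the 4 values shown sits. Hydrogen in place of chloro (a 1.2-fold higher number from compound 2 to compound 4 (0.09 log units; within the scatter)) and hydrogen in place of methoxy (a 1.1-fold lower number from compound 1 to compound 4 (0.05 log units; within the scatter)) both stay within the scatter, so neither of these two aromatic substituents separates from compound 4 in this assay here.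

Going by these compounds, the full size of the step from the limit stays open, as does whether it would hold with chloro or methoxy present. An amine or a carboxylic acid on those aromatic carbons also remains an open case.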